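The compounds below may be only part of what the source reports. "The series", "measured", "known", "first", "only" and "open" are said of these compounds alone.

Measured in a functional assay on ID8 cells (Mus musculus) for antiproliferative activity; on this read-out higher numbers stand for weaker inhibition and lower numbers for stronger inhibition:
- Compound 1 `O=c1cc(-c2ccccc2Cl)oc2c(N3CCCCC3)ccc(O)c12`: 5700 nM
- Compound 2 `C[C@H](NC(=O)OC(C)(C)C)C(=O)Nc1ccc(O)c2c(=O)cc(-c3ccccc3Cl)oc12`: 9800 nM

Compound 2, at 9800 nM, lies within the usual scatter of compound 1, so the two cannot be told apart, although their groups differ. Compound 3 `CCC(C)OC(=O)Nc1ccc(O)c2c(=O)cc(-c3ccccc3Cl)oc12` has sec-butoxy in place of 1-((tert-butoxycarbonyl)amino)ethyl on a carbonyl carbon. Going by the values given here, no measured pair shows this change, so the only guide is the closeness of these two values. In this assay, no step beyond the scatter is expected, and the estimate means a 1.4-fold lower number from compound 2 to compound 3 (0.15 log units; within the scatter). The expected value for compound 3 is 7000 nM, within an estimated range of 2500 nM to 20000 nM.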

Compound 3, half-maximal inhibitory concentration: 18000 nM
Beside the measured number, compound 3's estimate is 2.6-fold (0.41 log units) below it, within the range that was stated.
By their numbers in this assay, from the lowest: compounds 1, 2 and 3 (each within the scatter of the next, the first and the last beyond it).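

In this assay, putting sec-butoxy in place of 1-((tert-butoxycarbonyl)amino)ethyl on a carbonyl carbon gives a step too small to read (a 1.8-fold higher number from compound 2 to compound 3 (0.26 log units; within the scatter)), so this smaller group cannot be told apart from the larger one. Going by these compounds alone, the change of (sec-butoxycarbonyl)amino in place of piperidin-1-yl on an aromatic carbon gives the first step beyond the scatter, a modest one (a 3.2-fold higher number from compound 1 to compound 3 (0.50 log units; beyond the scatter)). Nothing measured here offers a reason for either number. Still open, from the compounds shown here alone, is how a simple amine on that carbonyl carbon would read, or a longer chain in place of sec-butoxy.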